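This account rests on a few compounds, and the source may have more. Where it says the series, first, only, none or still open, it means among the compounds named here.

In a functional assay on HepG2 cells (Homo sapiens) for cytotoxicity, read by MTT assay (a higher number here means a weaker inhibitor, a lower number a stronger inhibitor), three compounds built on one shared core have been measured. Compound 1 `COc1ccc(/C=C/C(=O)c2ccc(OC)c3c2OC(C)(C)C=C3)cc1O`, with a hydrogen on the oxygen on the aromatic ring, gives 450 nM. Compound 2 `CCCCC(=O)Oc1cc(/C=C/C(=O)c2ccc(OC)c3c2OC(C)(C)C=C3)ccc1OC`, with butylcarbonyl on that oxygen, gives 100 nM. Compound 3 `COc1ccc(/C=C/C(=O)Oc2cc(/C=C/C(=O)c3ccc(OC)c4c3OC(C)(C)C=C4)ccc2OC)cc1`, with (2-(4-methoxyphenyl)ethenyl)carbonyl there, gives 430 nM. Compound 3 therefore sits level with compound 1 and well above compound 2 on these numbers.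

The next structure is compound 4 `COc1ccc(/C=C/C(=O)c2ccc(OC)c3c2OC(C)(C)C=C3)cc1OC(=O)c1ccco1`, and the change is furan-2-yl in place of 2-(4-methoxyphenyl)ethenyl on a carbonyl carbon. In words, furan-2-yl stands in place of 2-(4-methoxyphenyl)ethenyl on a carbonyl carbon.

Among the measured compounds shown here, no measured compound carries furan-2-yl, so the evidence is indirect. For the measured compounds named here, the closest precedent is the exchange at the same carbonyl carbon, a 4.3-fold higher number from compound 2 to compound 3 (0.63 log units; beyond the scatter), which shows that the group held there can shift the number. The two steps at the oxygen, a 4.5-fold lower number from compound 1 to compound 2 (0.65 log units; beyond the scatter) and a 1.0-fold lower number from compound 1 to compound 3 (0.02 log units; within the scatter), show that adding a carbonyl group there does not by itself settle the outcome. A value inside the span of the three measured compounds therefore seems the most reasonable expectation, leaning slightly toward lower numbers. The expected change is a 1.9-fold lower number from compound 3 to compound 4 (0.27 log units; within the scatter). Compound 4 is estimated at 230 nM, with an expected range of 80 nM to 600 nM.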

Compound 4, half-maximal inhibitory concentration: 370 nM
Beside the measured number, compound 4's estimate is 1.6-fold (0.21 log units) below it, and the stated range covers the measured number.
By their numbers in this assay, from the lowest: compound 2; then compounds 4, 3 and 1 (each within the scatter of the next).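

In this assay, furan-2-yl on the carbonyl carbon changes little against the much larger 2-(4-methoxyphenyl)ethenyl, with a 1.2-fold lower number from compound 3 to compound 4 (0.07 log units; within the scatter), so the size of the group that leaves does not by itself move the number in this pair. The separation from butyl persists, with a 3.7-fold higher number from compound 2 to compound 4 (0.57 log units; beyond the scatter), while the step from the free hydrogen on the oxygen, a 1.2-fold lower number from compound 1 to compound 4 (0.09 log units; within the scatter), shows that (furan-2-yl)carbonyl, like (2-(4-methoxyphenyl)ethenyl)carbonyl, leaves compound 4 level with compound 1, so that among these four compounds only compound 2, with butylcarbonyl, stands apart. Nothing available offers an independent measurement that would explain why this one group differs from the other two.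

The compounds shown do not tell whether the lower number of compound 2 belongs to an open carbon chain in general or to butyl alone, a question that a propyl or hexyl chain on the same carbonyl carbon would address. They also leave open whether a plain phenyl group there would stay level with furan-2-yl, and whether an amine on that carbonyl carbon would behave like either kind of group.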